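One Added Ring on a Shared Core

The source may report more compounds than this note shows. Statements on the series, on what has been measured and on what is new or still open speak of the compounds shown alone.

In an ADME assay on microsomes from liver (Homo sapiens) for metabolic stability, read by LC-MS, with a stated time of 10 min (a higher number here means that more of the compound is left, a lower number that less of the compound is left), compound 1 (`CN(C[C@H]1Cc2c(cccc2N2CCN(C3CC3)CC2)CN1)[C@H]1CCCc2cccnc21`) gives 15.5% and compound 2 (`CN(C[C@H]1Cc2c(cccc2N2CCNC(C)(C)C2)CN1)[C@H]1CCCc2cccnc21`) gives 100% while compound 3 (`CC(C)N1CCN(c2cccc3c2C[C@H](CN(C)[C@H]2CCCc4cccnc42)NC3)CC1`) gives 56.6% and so stands second highest of the three. Compound 4 (`CN(C[C@H]1Cc2c(cccc2N2CCN3CCC[C@H]3C2)CN1)[C@H]1CCCc2cccnc21`) keeps the shared core and differs from compound 3 in a single group. The change is a group of 9 heavy atoms (7 carbon, 2 nitrogen; one five-membered non-aromatic ring with 1 hetero atom, one six-membered non-aromatic ring with 2 hetero atoms) in place of a group of 9 heavy atoms (7 carbon, 2 nitrogen; one six-membered non-aromatic ring with 2 hetero atoms), on an aromatic carbon and it sits on an aromatic carbon.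

Among the measured compounds shown here, three measured steps bear on this same place, and all are large: a number 41.1 percentage points higher from compound 1 to compound 3 (beyond the scatter) with isopropyl in place of cyclopropyl on the ring amine nitrogen, a number 84.5 percentage points higher from compound 1 to compound 2 (beyond the scatter) with 3,3-dimethylpiperazin-1-yl entering, and a number 43.4 percentage points lower from compound 2 to compound 3 (beyond the scatter) with 4-isopropylpiperazin-1-yl entering. None of them makes the present change, so they show how far values have moved here but not which way this one will go. The only hint is weak: compound 1, with cyclopropyl as a second ring in its group, sits lowest at 15.5% and the entering group also carries a second ring. A moderate downward move is therefore expected, with a number 11.6 percentage points lower from compound 3 to compound 4 (beyond the scatter) as the estimated size and a wide margin either way. In this assay the estimate for compound 4 is 45% with an expected range from 20% to 75%.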

Compound 4, percent of the compound remaining: 36.6%
The estimate for compound 4 lay 8.4 percentage points above the measured number, and the stated range covers the measured number.
By their numbers in this assay, from the lowest: compound 1; then compound 4; then compound 3; then compound 2.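

The entering group matches 4-isopropylpiperazin-1-yl in heavy atoms, nitrogens, hydrogen-bond donors and acceptors, yet the swap still gives a number 20 percentage points lower from compound 3 to compound 4 (beyond the scatter) in this assay, so at this position on the aromatic carbon those counts alone do not fix the number. A second ring in the group does not fix it either: the two compounds that carry one still sit apart, with a number 21.1 percentage points higher from compound 1 to compound 4 (beyond the scatter), while the single-ring group of compound 2 stays well clear, with a number 63.4 percentage points lower from compound 2 to compound 4 (beyond the scatter) as the step. Nothing available here explains why the numbers move this way.

On these data alone, how a morpholine or a 4-methylpiperazin-1-yl group at this position would fall in this order remains open, as does whether the opposite arrangement at the one defined stereocentre of the entering group would give the same number. The compounds shown also leave open which part of each molecule changes during this assay, and so whether the group at this position is itself where that change happens.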